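This account rests on a few compounds, and the source may have more. Where it says the series, first, only, none or still open, it means among the compounds named here.

The compounds share one core and were all tested in a functional assay on HT-29 cells (Homo sapiens) for antiproliferative activity, read by MTT assay, with a stated time of 72 h; a lower number here means a stronger inhibitor, a higher number a weaker inhibitor. Compound 1 `O=C(Nc1ccc(Oc2ccnc3[nH]ccc23)cc1)c1cc2cccnc2n(-c2ccc(F)cc2)c1=O` carries a fluoro group on one of its rings, and in this assay compound 1 gives 160 nM. Compound 2 `O=C(Nc1ccc(Oc2ccnc3[nH]ccc23)cc1)c1cc2cccnc2n(-c2ccc(Br)cc2)c1=O` has bromo in that same place, and in this assay compound 2 gives 270 nM. Compound 3 `COc1ccc(-n2c(=O)c(C(=O)Nc3ccc(Oc4ccnc5[nH]ccc45)cc3)cc3cccnc32)cc1` carries methoxy there, and in this assay compound 3 gives 1260 nM. Among these three numbers compound 2 stands second highest: the step of a 1.7-fold higher number from compound 1 to compound 2 (0.23 log units; within the scatter) lies within the scatter, whereas the steps of a 4.7-fold higher number from compound 2 to compound 3 (0.67 log units; beyond the scatter) and a 7.9-fold higher number from compound 1 to compound 3 (0.90 log units; beyond the scatter) lie beyond it.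

Compound 4 `O=C(Nc1ccc(Oc2ccnc3[nH]ccc23)c(F)c1)c1cc2cccnc2n(-c2ccc(Br)cc2)c1=O` has not yet been measured. It differs from compound 2 by fluoro in place of hydrogen on an aromatic carbon; the fluoro enters on an aromatic carbon of a six-membered aromatic ring of carbon only, ortho to a large group and meta to a large group, and this is a different ring from the one where the three measured compounds vary. Among the measured compounds shown here, none of the measured steps touches this ring, so none bears directly on the new change; the only guidance is that the swap of fluoro for bromo in a 1.7-fold higher number from compound 1 to compound 2 (0.23 log units; within the scatter) stayed within the scatter. Compound 4 is therefore expected to show a step of no change at the digits printed from compound 2 to compound 4 (within the scatter), nothing beyond the scatter. The estimate for compound 4 is 270 nM, with an expected range from 110 nM to 650 nM.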

Compound 4, half-maximal inhibitory concentration: 120 nM
For compound 4 the middle estimate is 2.3-fold (0.35 log units) above the measured one, and the stated range covers the measured number.
By their numbers in this assay, from the lowest: compounds 4, 1 and 2 (each within the scatter of the next, the first and the last beyond it); then compound 3.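

In this assay, fluoro in place of hydrogen gives a 2.3-fold lower number from compound 2 to compound 4 (0.35 log units; beyond the scatter), a modest step but one beyond the scatter, in the direction of a stronger inhibitor. Among the compounds shown here, this is the first sign that the six-membered aromatic ring of carbon only, untouched in the earlier compounds, also responds to substitution: a single fluorine atom, ortho to a large group and meta to a large group, is enough to shift the number. Nothing available here explains this shift.

On these data alone, this step comes from a single pair with bromo on the other varied ring, so it remains open whether the same fluoro change would have a similar effect alongside the fluoro or methoxy seen on that ring in compound 1 and compound 3. It is equally open whether this place is specific to fluoro, since the compounds shown say nothing about how chloro, methyl or an amine would behave there, or about fluoro on the other carbons of this ring.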